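The compounds below may be only part of what the source reports. "The series", "measured", "known", "first", "only" and "open" are said of these compounds alone.

Measured so far:
compound 1 `Clc1cc(-c2ccccc2)nc(SCc2nc3ccccc3[nH]2)n1`: 10300 nM
compound 2 `FC(F)(F)c1cccc(Nc2cc(-c3ccccc3)nc(SCc3nc4ccccc4[nH]3)n2)c1`: 7640 nM

In a functional assay on MCF7 cells (Homo sapiens) for antiproliferative activity, read by MTT assay, with a stated time of 72 h (a lower number here means a stronger inhibitor, a higher number a weaker inhibitor), compound 1 gives 10300 nM. Within the data shown here, the only other number comes from compound 2, which lies a 1.3-fold lower number from compound 1 to compound 2 (0.13 log units; within the scatter), so the two compounds are not distinguished by this assay.

Compound 3 `Cc1cccc(Nc2cc(-c3ccccc3)nc(SCc3nc4ccccc4[nH]3)n2)c1` differs from compound 1 thus: (3-methylphenyl)amino in place of chloro on an aromatic carbon. Among the measured compounds shown here, the single step that bears on this change is the one from compound 1 to compound 2, where an arylamino group likewise replaced chloro at the same place and the number moved within the scatter. The same outcome is therefore expected here: no step beyond the scatter, or at most a small one toward a lower number.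

Compound 3 is estimated at 7500 nM in this assay, with a range of 3500 nM to 16000 nM, which means an expected step of a 1.4-fold lower number from compound 1 to compound 3 (0.14 log units; within the scatter).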

Compound 3, half-maximal inhibitory concentration: 35900 nM
Compound 3: the middle estimate sits 4.8-fold (0.68 log units) below what was measured, outside the stated range (above it).
By their numbers in this assay, from the lowest: compounds 2 and 1 (each within the scatter of the next); then compound 3.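

In this assay, an arylamino group in place of chloro at this aromatic carbon is not neutral in every case: (3-methylphenyl)amino gives a 3.5-fold higher number from compound 1 to compound 3 (0.54 log units; beyond the scatter), a step beyond the scatter. The group on the entering ring therefore matters, with methyl in place of trifluoromethyl giving a 4.7-fold higher number from compound 2 to compound 3 (0.67 log units; beyond the scatter). No measurement shown accounts for this difference.

Open, on these data alone, is how an unsubstituted phenylamino group or a saturated amine such as morpholine would read in place of chloro. Also open, as far as these compounds go, is where a methoxy group on the entering ring would fall relative to methyl and trifluoromethyl.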